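The source may report more compounds than this note shows. Statements on the series, on what has been measured and on what is new or still open speak of the compounds shown alone.

Measured in an ADME assay on L02 cells (Homo sapiens) for cytotoxicity, read by MTT assay, with a stated time of 48 h; a lower number here means a stronger inhibitor, a higher number a weaker inhibitor:
- compound 1, `CCN1CCN(C[C@H]2CN(c3ccc(-n4cc(-c5ccccn5)cn4)c(F)c3)C(=O)O2)CC1`: 99 ug/mL
- compound 2, `O=C1O[C@@H](Cn2ccnc2)CN1c1ccc(-n2cc(-c3ccccn3)cn2)c(F)c1`: 350 ug/mL
- compound 3, `CN(C)S(=O)(=O)NC[C@H]1CN(c2ccc(-n3cc(-c4ccccn4)cn3)c(F)c2)C(=O)O1`: 158 ug/mL

Compound 3 has the second highest of the three numbers in this assay. Its nearest neighbour is compound 1, which sits at a step of a 1.6-fold higher number from compound 1 to compound 3 (0.20 log units; within the scatter); the further one is compound 2, separated by a 2.2-fold lower number from compound 2 to compound 3 (0.35 log units; beyond the scatter). Compound 4, `CNC(=O)[C@H]1CN(c2ccc(-n3cc(-c4ccccn4)cn3)c(F)c2)C(=O)O1`, differs from compound 3 by methylcarbamoyl in place of ((dimethylsulfamoyl)amino)methyl on a saturated ring carbon: the side chain is cut back to a small amide borne directly on the ring carbon that sits next to the ring oxygen.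

Among the compounds with values here, no measured step makes this same exchange, so the steps that bear on it are those that vary the group at this position in the shared core: from compound 1 to compound 3 the step was within the scatter, and from compound 2 to compound 3 it was modest. Together they show that changing this group moves the number only a little. The step from compound 3 to compound 4 is therefore expected to be small, a 1.1-fold higher number from compound 3 to compound 4 (0.06 log units; within the scatter), with no clear direction. Compound 4 is estimated at 180 ug/mL, within a range from 80 ug/mL to 400 ug/mL.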

Compound 4, half-maximal inhibitory concentration: 217 ug/mL
Compound 4: the middle estimate sits 1.2-fold (0.08 log units) below what was measured; the measured number falls inside the stated range.
By their numbers in this assay, from the lowest: compounds 1, 3, 4 and 2 (each within the scatter of the next, the first and the last beyond it).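

In this assay, methylcarbamoyl, with 4 heavy atoms against the 8 of ((dimethylsulfamoyl)amino)methyl, can sit on this saturated ring carbon without a clear change: the step is a 1.4-fold higher number from compound 3 to compound 4 (0.14 log units; within the scatter), and the exchange for (1H-imidazol-1-yl)methyl gives a 1.6-fold lower number from compound 2 to compound 4 (0.21 log units; within the scatter). Only the comparison with the (4-ethylpiperazin-1-yl)methyl group passes the scatter, and modestly, at a 2.2-fold higher number from compound 1 to compound 4 (0.34 log units; beyond the scatter), so among these four compounds a much smaller group at this position does not produce a large shift in either direction. Nothing available gives a reason for these small differences.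

The compounds shown leave open whether a carboxylic acid or a primary amine on this ring carbon would stay in the same narrow band of numbers. They also leave open whether a longer chain on the amide nitrogen of methylcarbamoyl, or a second methyl in place of the amide hydrogen, would move the number.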